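Swapping the ring on the piperazine nitrogen

The source may report more compounds than this note shows. Statements on the series, on what has been measured and on what is new or still open speak of the compounds shown alone.

Measured compounds in a functional assay, read by spectrophotometry, with a stated time of 30 min, tested at 25 ug/mL; a lower number here means a weaker effect, a higher number a stronger effect of the compound at the concentration tested:
- compound 1, `CN1CCN(CC(=O)Nc2nc3ccccc3[nH]2)CC1`, gives 19.9%
- compound 2, `O=C(CN1CCN(c2ccccn2)CC1)Nc1nc2ccccc2[nH]1`, gives 40.9%
- compound 3, `O=C(CN1CCN(c2ncccn2)CC1)Nc1nc2ccccc2[nH]1`, gives 20.4%

Compound 2 stands highest of the three numbers, with compound 3 nearest below it and compound 1 furthest. Compound 4, `COc1ccccc1N1CCN(CC(=O)Nc2nc3ccccc3[nH]2)CC1`, has not been measured; it differs from compound 2 in one place: 2-methoxyphenyl in place of pyridin-2-yl on an amine nitrogen in a ring.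

Within the data shown here, two measured steps touch the same position. The step of a number 21 percentage points higher from compound 1 to compound 2 (beyond the scatter) shows that putting pyridin-2-yl in place of methyl raised the read-out, while the step of a number 20.5 percentage points lower from compound 2 to compound 3 (beyond the scatter) shows that exchanging pyridin-2-yl for pyrimidin-2-yl brought it back down. Among the measured compounds shown here, a six-membered aromatic ring at this position therefore is not by itself enough for the higher number; which ring it is matters, and no measured compound carries 2-methoxyphenyl there. The expectation is a modest fall for compound 4, expressed as a number 10.9 percentage points lower from compound 2 to compound 4 (beyond the scatter), with a wide range. Compound 4 is estimated at 30%, between 12% and 52%.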

Compound 4, a percentage reported as activity, at one concentration (the size of the read-out at that concentration, not a potency): 21.3%
For compound 4 the middle estimate is 8.7 percentage points above the measured one, and the stated range covers the measured number.
By their numbers in this assay, from the lowest: compounds 1, 3 and 4 (each within the scatter of the next); then compound 2.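

Replacing pyridin-2-yl with 2-methoxyphenyl gives a number 19.6 percentage points lower from compound 2 to compound 4 (beyond the scatter) in this assay and so adds a second ring, this one of carbon only, that lacks the higher number of compound 2. The other two steps are a number 0.9 percentage points higher from compound 3 to compound 4 (within the scatter) and a number 1.4 percentage points higher from compound 1 to compound 4 (within the scatter) in the same assay, which means that methyl, pyrimidin-2-yl and 2-methoxyphenyl cannot be told apart here, and among these four groups only pyridin-2-yl stands out. No measurement at hand accounts for what sets pyridin-2-yl apart.

Still open, as far as these compounds go, is how plain phenyl or pyridin-4-yl would read on this same ring nitrogen. Such groups could help show whether the ring nitrogen of pyridin-2-yl or the methoxy group of 2-methoxyphenyl separates compound 2 from compound 4.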